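A few compounds are considered here, and "the series" means these few. Any claim that something is new, unique, unknown or untested is made for them only; others in the source may bear on it.

In an assay on Sf9 cells for inhibition of histone deacetylase 11 (Homo sapiens), read by fluorescence, tested at 0.5 uM (a higher number here means more inhibition at the concentration tested (going by the name of the read-out), a lower number less inhibition), compound 1 `O=C(/C=C/c1cn([C@@H]2C[C@H](CO)N(CCCc3ccccc3)C2)nn1)NO` gives 12%. In this assay compound 2 `O=C(NO)c1ccc(-c2cn([C@@H]3C[C@H](CO)N(CCCc4ccccc4)C3)nn2)cc1` gives 15%. The change between them is 4-(hydroxycarbamoyl)phenyl in place of 2-(hydroxycarbamoyl)ethenyl on an aromatic carbon, and the step was a number 3 percentage points higher from compound 1 to compound 2 (within the scatter). Compound 3 `O=C(/C=C/c1cn([C@H]2C[C@H](C(=O)O)N(Cc3ccccc3)C2)nn1)NO` gives 14% in this assay; how its core differs from the core of compound 1 is not broken down here. Compound 4 `O=C(NO)c1ccc(-c2cn([C@H]3C[C@H](C(=O)O)N(Cc4ccccc4)C3)nn2)cc1` is not yet measured. It differs from compound 3 by 4-(hydroxycarbamoyl)phenyl in place of 2-(hydroxycarbamoyl)ethenyl on an aromatic carbon, the same change made once before, at the same place. Since the earlier step was a number 3 percentage points higher from compound 1 to compound 2 (within the scatter), the new step is expected to be small as well, estimated as a number 3 percentage points higher from compound 3 to compound 4 (within the scatter). Compound 4 is therefore expected to give about 17% in this assay, estimated to fall between 7% and 27%.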

Compound 4, a percentage reported as inhibition, at one concentration (the size of the read-out at that concentration, not a potency): < 10%
Compound 4: only a limit was reported; the forecaster's own chance of this, stated with the estimate: 0%; middle value at least 7 percentage points from the limit.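

In this assay, putting 4-(hydroxycarbamoyl)phenyl in place of 2-(hydroxycarbamoyl)ethenyl on the core of compound 3 gives a number at least 4 percentage points lower from compound 3 to compound 4 (that floor lies within the scatter). Compound 4 gives < 10%, which is a limit of the assay and not a number. The change therefore cannot be said either to carry over between the two cores or to behave differently on them: the same change on two cores in this assay, a number 3 percentage points higher (within the scatter) from compound 1 to compound 2 and a number at least 4 percentage points lower (that floor lies within the scatter) from compound 3 to compound 4; the limit leaves it open whether they differ

The compounds shown leave open whether any difference between the core of compound 1 and the core of compound 3 affects this change at all. They also leave open how the same change would read on a core bearing an ester or an amide in place of the carboxylic acid of compound 3.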